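Thiazolidinedione and rhodanine phthalimide ethers: alpha-glucosidase series

The source may hold more compounds than are shown below. What is called first, only, known or untested is meant among the compounds shown, and "the series" means these compounds.

Compound 1 `O=C1NC(=O)/C(=C/c2ccccc2OCN2C(=O)c3ccccc3C2=O)S1` carries a thiazolidinedione arm on the shared core. In an assay on isolated protein for inhibition of Alpha glucosidase (Homo sapiens), read by spectrophotometry, with stated times of 15 min and 30 min (on this read-out higher numbers stand for weaker inhibition and lower numbers for stronger inhibition), compound 1 gives only a limit, > 100000 nM, not a number. Compound 2 `COc1cccc(/C=C2\SC(=O)NC2=O)c1OCN1C(=O)c2ccccc2C1=O` adds a methoxy group to the aromatic ring of compound 1. In this assay compound 2 likewise returns only the limit > 100000 nM. Compound 3 `O=C1NC(=S)S/C1=C\c1ccccc1OCN1C(=O)c2ccccc2C1=O` replaces the thiazolidinedione of compound 1 with a rhodanine. In this assay compound 3 also stands at the limit > 100000 nM, so for compound 3 only a bound is known, no number. The two steps from compound 1, a step that the two limits leave unreadable from compound 1 to compound 2 and a step that the two limits leave unreadable from compound 1 to compound 3, are therefore unreadable in size, since the limit of > 100000 nM in this assay, at which 3 of the 3 values shown sit, holds every value seen so far.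

Compound 4 `COc1cccc(/C=C2\SC(=S)NC2=O)c1OCN1C(=O)c2ccccc2C1=O` is yet to be measured. It differs from compound 3 by methoxy in place of hydrogen on an aromatic carbon. For the measured compounds named here, the one step that bears on it, a step that the two limits leave unreadable from compound 1 to compound 2, is the same methoxy addition on the thiazolidinedione arm, and it gave no readable change. No readable step is available, so the expectation for compound 4 in this assay is simply that it stays where compound 3 stands, with the step that the limit leaves unreadable from compound 3 to compound 4 expected to be nothing beyond the scatter. Compound 4 is thus estimated at 150000 nM, within 40000 nM to 600000 nM, most likely reported again as a limit.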

Compound 4, half-maximal inhibitory concentration: > 100000 nM
Compound 4: no number, only a limit (the forecaster's own chance of this, stated with the estimate: 85%); the middle value does not contradict the limit.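

Compound 4 also returns only a limit in this assay, so its steps from compound 3 and from compound 2 cannot be read, and the series stays at that limit: the limit of > 100000 nM in this assay, at which 4 of the 4 values shown sit. The compounds shown leave open whether methoxy or the rhodanine in place of the thiazolidinedione has any effect on inhibition in this assay.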